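Replacing an Ethylamide with a Methylpiperidine Amide

This account rests on a few compounds, and the source may have more. Where it says the series, first, only, none or still open, it means among the compounds named here.

Compound 1 `CCNC(=O)/C=C/c1c(/C=C/c2ccc(OC)cc2)cc(OC)cc1OC`: 6990 nM
Compound 2 `CCCCCCCCNC(=O)/C=C/c1c(/C=C/c2ccc(OC)cc2)cc(OC)cc1OC`: 8060 nM
Compound 3 `CCC(C)NC(=O)/C=C/c1c(/C=C/c2ccc(OC)cc2)cc(OC)cc1OC`: 4380 nM

Three amides built on a shared core have been tested in a functional assay on B16-F10 cells (Mus musculus) for inhibition, read by MTT assay, with a stated time of 48 h; a lower number here means a stronger inhibitor, a higher number a weaker inhibitor. Among these three numbers compound 1 stands second highest. Its nearest neighbour is compound 2, with a 1.2-fold higher number from compound 1 to compound 2 (0.06 log units; within the scatter), and its furthest is compound 3, with a 1.6-fold lower number from compound 1 to compound 3 (0.20 log units; within the scatter). Between the two larger amides the step is a 1.8-fold lower number from compound 2 to compound 3 (0.26 log units; within the scatter). All three steps stay inside the usual scatter, so the three amides are, on this evidence, indistinguishable.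

Compound 4 `COc1ccc(/C=C/c2cc(OC)cc(OC)c2/C=C/C(=O)N2CCCC(C)C2)cc1` has not yet been measured. It differs from compound 1 in one place: 3-methylpiperidin-1-yl in place of ethylamino on a carbonyl carbon. The measured steps all concern what hangs on the amide nitrogen as an open chain, and none of them moved the number beyond the scatter. The change to compound 4 is of the same family but goes further, closing the nitrogen into a ring and removing the hydrogen-bond donor. Within the data shown here, with no measured step reaching beyond the scatter, the expectation for compound 4 is a number close to that of compound 1, estimated at 6500 nM with a range from 2500 nM to 17000 nM. The step this estimate implies is a 1.1-fold lower number from compound 1 to compound 4 (0.03 log units; within the scatter), expected to stay within the scatter.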

Compound 4, half-maximal inhibitory concentration: 8250 nM
Estimate against measurement, compound 4: 1.3-fold (0.10 log units) below; the range from low to high includes it.
By their numbers in this assay, from the lowest: compounds 3, 1, 2 and 4 (each within the scatter of the next).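

Closing the amide nitrogen into the 3-methylpiperidin-1-yl ring removes the amide hydrogen, yet this assay shows only a 1.2-fold higher number from compound 1 to compound 4 (0.07 log units; within the scatter) against the ethylamino group. The comparisons with the other two open-chain amides read the same way, with a 1.9-fold higher number from compound 3 to compound 4 (0.27 log units; within the scatter) and a 1.0-fold higher number from compound 2 to compound 4 (0.01 log units; within the scatter) as the steps, so among these four compounds neither the amide hydrogen nor an open chain on the nitrogen is needed for a number of this size. Nothing at hand explains this result.

From the compounds shown here alone, all four amides lie within the scatter of one another, so it remains open whether any change at this carbonyl carbon can move the number beyond it. A carboxylic acid in place of the amide, or a piperazine ring on the carbonyl carbon, would test this with a larger change.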